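A Methylsulfonyl Group Tested Against a Methyl

The source may report more compounds than this note shows. Statements on the series, on what has been measured and on what is new or still open speak of the compounds shown alone.

Compound 1 `O=S(=O)(Nc1cccc(CO)c1)c1ccc(-c2ccc(Cl)cc2)cc1` gives 2500 nM in a functional assay on J774 cells (Mus musculus) for cytotoxicity, read by resazurin assay, with a stated time of 72 h; a lower number here means a stronger inhibitor, a higher number a weaker inhibitor.
Compound 2 `Cc1ccc(-c2ccc(S(=O)(=O)Nc3cccc(CO)c3)cc2)cc1` gives 1200 nM in this assay.

Among the compounds with values here, compound 2 stands lowest of the two numbers, and the only measured step is a 2.1-fold lower number from compound 1 to compound 2 (0.32 log units; beyond the scatter). Compound 3 `CS(=O)(=O)c1ccc(-c2ccc(S(=O)(=O)Nc3cccc(CO)c3)cc2)cc1` differs from compound 2 in one place: methylsulfonyl in place of methyl on an aromatic carbon. Within the data shown here, the one step that bears on this position, a 2.1-fold lower number from compound 1 to compound 2 (0.32 log units; beyond the scatter), was modest yet beyond the scatter. Among the measured compounds shown here, no measured step shows this group directly, so the analyst expects a modest step in this assay, more likely toward a higher number. For compound 3 the estimate is 2500 nM, with a range from 900 nM to 7000 nM. That expected value corresponds to a 2.1-fold higher number from compound 2 to compound 3 (0.32 log units; beyond the scatter).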

Compound 3, half-maximal inhibitory concentration: > 5000 nM
Compound 3: no number, only a limit (the forecaster's own chance of this, stated with the estimate: 5%); middle value at least 2.0-fold (0.30 log units) away from the limit.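

The position is not limited to small shifts: methylsulfonyl in place of methyl on an aromatic carbon gives an at least 4.1-fold higher number from compound 2 to compound 3 (0.61 log units; beyond the scatter), a step in the opposite direction to a 2.1-fold lower number from compound 1 to compound 2 (0.32 log units; beyond the scatter). Methylsulfonyl in place of chloro gives an at least 2.0-fold higher number from compound 1 to compound 3 (0.30 log units; that floor lies within the scatter), so this floor alone does not set the two compounds clearly apart. The result for compound 3 is a limit, not a number: the limit of > 5000 nM in this assay, at which 1 of the 3 values shown sits. Where the actual number of compound 3 lies remains open. So does how an amine or a carboxylic acid at this position would read in this assay.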